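A few compounds are considered here, and "the series" means these few. Any claim that something is new, unique, unknown or untested is made for them only; others in the source may bear on it.

Measured compounds in a functional assay on MGC-803 cells (Homo sapiens) for inhibition, read by MTT assay, with a stated time of 72 h, tested at 10 uM; a higher number here means more inhibition of growth at the concentration tested, a lower number less inhibition of growth:
compound 1, `O=C(/C=C/c1ccc(Oc2ncnc3ccc(Cl)cc23)cc1)/C=C/c1cc([N+](=O)[O-])ccc1Cl`: 86.7%
compound 2, `O=C(/C=C/c1ccc(Cl)c([N+](=O)[O-])c1)/C=C/c1ccccc1Oc1ncnc2ccc(Cl)cc12`: 70.2%
compound 3, `O=C(/C=C/c1ccc(Oc2ncnc3ccc(Cl)cc23)cc1)/C=C/c1ccc(Cl)c([N+](=O)[O-])c1`: 66.2%

Compound 2 stands second highest of the three. Compound 3 lies within the scatter of compound 2, whereas compound 1 sits beyond the scatter above it. Compound 4 `O=C(/C=C/c1ccccc1Oc1ncnc2ccc(Cl)cc12)/C=C/c1cccc(Cl)c1Cl` is not yet measured; relative to compound 2 the change is 2,3-dichlorophenyl in place of 4-chloro-3-nitrophenyl on a double-bonded chain carbon bound to a double-bonded chain carbon. Among the measured compounds shown here, the one measured step on that chain carbon is a number 20.5 percentage points lower from compound 1 to compound 3 (beyond the scatter), which exchanged one chloro-nitrophenyl pattern for another and so bears only loosely on a replacement by 2,3-dichlorophenyl. A step of comparable modest size in this assay seems plausible, direction uncertain; a small loss is expected, a number 8.2 percentage points lower from compound 2 to compound 4 (within the scatter). Compound 4 is estimated at 62%, within 45% to 78%.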

Compound 4, percent growth inhibition at one concentration: 76.5%
Compound 4: middle estimate off by 14.5 percentage points, on the low side; the range from low to high includes it.
By their numbers in this assay, from the lowest: compounds 3, 2 and 4 (each within the scatter of the next, the first and the last beyond it); then compound 1.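

With 2,3-dichlorophenyl in place of 4-chloro-3-nitrophenyl on a double-bonded chain carbon bound to a double-bonded chain carbon, this assay shows a number 6.3 percentage points higher from compound 2 to compound 4 (within the scatter). The earlier step only exchanged one chloro-nitrophenyl pattern for another, whereas this one shows that a ring with 0 hydrogen-bond acceptors can stand at this place without a change beyond the scatter. Nothing available gives a reason for this result.

Going by these compounds, whether the exchange reads the same on the core of compound 1 stays open. Also open, on these data alone, is how a phenyl ring carrying an amine or a carboxylic acid would compare at this place.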